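A few compounds are considered here, and "the series" means these few. Any claim that something is new, unique, unknown or untested is made for them only; others in the source may bear on it.

Measured compounds:
- compound 1, `CCCCOC(=O)c1cccc(-c2cc(C(=O)Nc3ccncc3)ccc2CN)c1`: 5.5 nM in an assay on isolated protein for inhibition of Rho-associated protein kinase 2 (Homo sapiens), read by radiometric assay; on this read-out lower numbers stand for stronger inhibition and higher numbers for weaker inhibition
- compound 2, `NCc1ccc(C(=O)Nc2ccncc2F)cc1-c1cccc(C(=O)OCCO)c1`: 1.4 nM in this assay

In this assay compound 2 gives the lower of the two numbers, and the gap to compound 1 lies beyond the usual scatter. Compound 1 and compound 2 differ in two places at once, on the ester tail and on the pyridine ring, so the two values cannot be split into a step for either place alone.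

Compound 3, `NCc1ccc(C(=O)Nc2ccncc2F)cc1-c1cccc(C(=O)OCC2CCCC2)c1`, keeps the core of compound 2 and changes only the ester tail: cyclopentyl in place of hydroxymethyl on a saturated chain carbon bound to an oxygen next to a carbonyl group. Within the data shown here, no measured pair isolates a change of this kind, so the direction of the step is open. Both measured compounds carry an ester tail of different make-up and both sit at low numbers in this assay, which suggests the tail tolerates variation; a step of modest size in either direction, or none beyond the scatter, is the working expectation.

Compound 3 is expected to give 2.5 nM in this assay, within 0.8 nM to 8 nM, which would be a step of a 1.8-fold higher number from compound 2 to compound 3 (0.25 log units; within the scatter).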

Compound 3, half-maximal inhibitory concentration: 13 nM
For compound 3 the middle estimate is 5.2-fold (0.72 log units) below the measured one; measured number above the stated range.
By their numbers in this assay, from the lowest: compound 2; then compound 1; then compound 3.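

In this assay, the ester tail now has its first readable single change: cyclopentyl in place of hydroxymethyl on a saturated chain carbon bound to an oxygen next to a carbonyl group gives a 9.3-fold higher number from compound 2 to compound 3 (0.97 log units; beyond the scatter). This position is therefore not indifferent to what the tail carries, since replacing 2-hydroxyethyl with cyclopentylmethyl, with the rest of compound 2 held constant, moves the number beyond the usual scatter. No supporting data bear on why this step occurs.

Compound 1 differs from both compound 2 and compound 3 in two places, so its steps to them cannot be read, and the separate contributions of its tail and its pyridine ring remain unresolved. The step from compound 2 to compound 3 also changes several features at once, including the hydroxyl group, the ring and the heavy-atom count, so tails such as 2-methoxyethyl, 2-aminoethyl or an open pentyl chain on the same core would be needed to show which of these features tracks with the higher number.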